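Cyclopropyl on the ring amide nitrogen of compound 2

The source may hold more compounds than are shown below. What is called first, only, known or untested is meant among the compounds shown, and "the series" means these compounds.

Compound 1 `COc1ncc(-c2ccc3c(c2)N(c2ccc(C)cc2)C(=O)CO3)cc1NS(=O)(=O)c1ccc(F)cc1`: 5870 nM
Compound 2 `COc1ncc(-c2ccc3c(c2)NC(=O)CO3)cc1NS(=O)(=O)c1ccc(F)cc1`: 8070 nM

In a functional assay on A549 cells (Homo sapiens) for antiproliferative activity, read by MTT assay, with a stated time of 72 h (a higher number here means a weaker inhibitor, a lower number a stronger inhibitor), compound 1 gives 5870 nM and compound 2 gives 8070 nM; the two values lie within the usual scatter of each other, so neither can be called the stronger. For the measured compounds named here, the only measured step, a 1.4-fold higher number from compound 1 to compound 2 (0.14 log units; within the scatter), bears directly on the change to compound 3 `COc1ncc(-c2ccc3c(c2)N(C2CC2)C(=O)CO3)cc1NS(=O)(=O)c1ccc(F)cc1`, which carries cyclopropyl in place of hydrogen on an amide-type nitrogen in a ring. Since replacing the large aryl group by hydrogen changed little, a small cyclopropyl is expected to change little too, giving an expected step of a 1.2-fold lower number from compound 2 to compound 3 (0.09 log units; within the scatter). Compound 3 is therefore estimated at 6500 nM, with a range from 2500 nM to 16000 nM.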

Compound 3, half-maximal inhibitory concentration: 3320 nM
Estimate against measurement, compound 3: 2.0-fold (0.29 log units) above; the measured number falls inside the stated range.
By their numbers in this assay, from the lowest: compounds 3, 1 and 2 (each within the scatter of the next, the first and the last beyond it).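

In this assay, for the compounds shown here, cyclopropyl in place of the amide hydrogen gives a 2.4-fold lower number from compound 2 to compound 3 (0.39 log units; beyond the scatter) and this is the first step at this nitrogen to clear the scatter. Cyclopropyl in place of 4-methylphenyl gives a 1.8-fold lower number from compound 1 to compound 3 (0.25 log units; within the scatter) so these two groups cannot be told apart here, and a substituent on this nitrogen need not be an aryl group. No measurement at hand explains the step. Still open, as far as these compounds go, is how an amine, a carboxylic acid or a longer chain on this nitrogen would compare with cyclopropyl.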